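A Hydroxymethyl Step Repeated on a Second Core

The compounds below may be only part of what the source reports. "The series", "measured", "known", "first", "only" and "open" are said of these compounds alone.

Three compounds have been measured in a physicochemical assay for lipophilicity; a higher number here means a more lipophilic compound, a lower number a more polar compound:

Compound 1, `Oc1cc2c(cc1CNc1ccccc1)OCCC2`, gives 3.5.
Compound 2, `OCc1ccccc1NCc1cc2c(cc1O)CCCO2`, gives 2.4.
Compound 3, `Oc1cc2ccoc2cc1CNc1ccccc1`, gives 3.3.

Compound 1 and compound 2 share a core and differ by hydroxymethyl in place of hydrogen on an aromatic carbon. In this assay that change produced a number 1.10 log units lower from compound 1 to compound 2 (beyond the scatter). Compound 3 is built on a different core, and the difference between the two cores is not broken down here; its value sits close to that of compound 1, within the usual scatter, so no order between the two can be claimed.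

Compound 4, `OCc1ccccc1NCc1cc2occc2cc1O`, has not yet been measured in this assay. For the measured compounds named here, it differs from compound 3 by hydroxymethyl in place of hydrogen on an aromatic carbon, which is the same change, at the same kind of place, as the one from compound 1 to compound 2. Because the earlier change gave a number 1.10 log units lower from compound 1 to compound 2 (beyond the scatter), a step of similar size is expected here, namely a number 1.10 log units lower from compound 3 to compound 4 (beyond the scatter). Starting from compound 3 at 3.3, compound 4 is therefore estimated at 2.2, with a likely range from 1.8 to 2.6.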

Compound 4, partition coefficient: 2.2
The estimate for compound 4 equals the measured number at the digits printed; the range from low to high includes it.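

In this assay, the change of hydroxymethyl in place of hydrogen on an aromatic carbon gave a number 1.10 log units lower from compound 3 to compound 4 (beyond the scatter) and, on the other core, a number 1.10 log units lower from compound 1 to compound 2 (beyond the scatter), so the step has the same size on both cores. For the compounds shown here, this supports carrying the step from one core to the other, but it rests on only two pairs of compounds, with the change at the same kind of place, and so says nothing about a third core or a different place on the ring. Nothing measured here bears on why the step has this size, so the agreement between the two pairs remains an observation without an explanation.

The compounds shown leave open whether another group at this place, such as an amine, a carboxylic acid or a longer chain like hydroxyethyl, would also give matching steps on the two cores. They also leave open whether hydroxymethyl would give a step of this size on a core of another kind.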